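Swapping the aryl group on the sulfonyl sulfur

This account rests on a few compounds, and the source may have more. Where it says the series, first, only, none or still open, it means among the compounds named here.

Going by the values given here, compound 2 `O=S(=O)(Nc1ccc2oc(-c3ccccc3)nc2c1)c1cccs1` is the only compound with a number in an assay on cells for inhibition of HSP60/HSP10 (Homo sapiens), with a stated time of 60 min (on this read-out lower numbers stand for stronger inhibition and higher numbers for weaker inhibition), where compound 2 gives 90000 nM. Compound 1 `O=S(=O)(Nc1ccc2oc(-c3ccccc3)nc2c1)c1cccc(Cl)c1` reaches only the limit of > 100000 nM in this assay, a limit marked by the limit of > 100000 nM in this assay, at which 1 of the 2 values shown sits. Among the compounds with values here, the one measured step, an at least 1.1-fold lower number from compound 1 to compound 2 (0.04 log units; that floor lies within the scatter), also exchanges the group on the sulfonyl sulfur and stays within the scatter. Compound 3 `O=S(=O)(Nc1ccc2oc(-c3ccccc3)nc2c1)c1ccc(O)cc1` differs from compound 2 by 4-hydroxyphenyl in place of thiophen-2-yl on a sulfonyl sulfur. Compound 3 is therefore expected to show no step beyond the scatter, no change at the digits printed from compound 2 to compound 3 (within the scatter). The estimated value of compound 3 is 90000 nM, expected between 25000 nM and 300000 nM.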

Compound 3, half-maximal inhibitory concentration: 88000 nM
Beside the measured number, compound 3's estimate is 1.0-fold (0.01 log units) above it; the measured number falls inside the stated range.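

Exchanging thiophen-2-yl for 4-hydroxyphenyl on the sulfonyl sulfur gives a 1.0-fold lower number from compound 2 to compound 3 (0.01 log units; within the scatter), so in this assay this place accepts a six-membered aromatic ring carrying a hydrogen-bond donor with no change beyond the scatter. The other step, an at least 1.1-fold lower number from compound 1 to compound 3 (0.05 log units; that floor lies within the scatter), gives only a floor. Compound 1 remains a limit and not a number: the limit of > 100000 nM in this assay, at which 1 of the 3 values shown sits.

As far as these compounds go, whether an amine or a carboxylic acid on this aromatic ring, or an alkyl chain in its place, would move the number beyond the scatter remains open. So does the effect of any change on the shared core.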